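The source may report more compounds than this note shows. Statements on the series, on what has been measured and on what is new or still open speak of the compounds shown alone.

Measured compounds:
Compound 1, `CSc1nnc(COc2cc(C)c3c(C)cc(=O)oc3c2)o1`: in a functional assay on MCF7 cells (Homo sapiens) for antiproliferative activity, read by MTT assay, with a stated time of 24 h (a lower number here means a stronger inhibitor, a higher number a weaker inhibitor), compound 1 gives only a limit, > 100000 nM.
Compound 2, `CCCCSc1nnc(COc2cc(C)c3c(C)cc(=O)oc3c2)o1`: in this assay compound 2 gives only a limit, > 100000 nM.
Compound 3, `CCS(=O)(=O)c1nnc(COc2cc(C)c3c(C)cc(=O)oc3c2)o1`: in this assay compound 3 gives only a limit, > 100000 nM.

Compound 3 therefore stands nowhere distinguishable from the other two; all three sit at the limit of > 100000 nM in this assay, at which 3 of the 3 values shown sit. The steps a step that the two limits leave unreadable from compound 1 to compound 2, a step that the two limits leave unreadable from compound 1 to compound 3 and a step that the two limits leave unreadable from compound 2 to compound 3 cannot be read in size or direction, so neither lengthening the sulfur chain nor moving to the sulfonyl has shown any readable effect.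

Compound 4, `Cc1cc(OCc2nnc(S(=O)(=O)Cc3cccc(F)c3)o2)cc2oc(=O)cc(C)c12`, differs from compound 3 by 3-fluorophenyl in place of methyl on a saturated chain carbon bound to a sulfonyl sulfur. Going by the values given here, none of the measured steps bears readably on this change. With nothing in the set showing measurable activity, compound 4 is expected to remain at the limit as well, so compound 4 is expected to show a number no higher from compound 3 to compound 4 (the limit leaves the size open). Compound 4 is estimated at 100000 nM, within 20000 nM to 500000 nM.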

Compound 4, half-maximal inhibitory concentration: 70400 nM
Estimate against measurement, compound 4: 1.4-fold (0.15 log units) above; measured number inside the range.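

At the saturated chain carbon bound to a sulfonyl sulfur, 3-fluorophenyl in place of methyl gives an at least 1.4-fold lower number from compound 3 to compound 4 (0.15 log units; that floor lies within the scatter). The floor of that step lies within the scatter, so the size of the change remains unsettled. Even so, compound 4 is the only compound shown that gives a number rather than a limit in this assay, and the others stay at that limit: the limit of > 100000 nM in this assay, at which 3 of the 4 values shown sit.

From the compounds shown here alone, it remains open how an unsubstituted benzyl or a 3-chlorobenzyl would read in place of 3-fluorobenzyl. Also open, going by these compounds, is whether a 3-fluorobenzyl on the sulfur of a sulfanyl compound would give a number at all.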